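A few compounds are considered here, and "the series" means these few. Any claim that something is new, unique, unknown or untested is made for them only; others in the source may bear on it.

Working notes on the series in a functional assay on NCI-H460 cells (Homo sapiens) for cytotoxicity, read by sulforhodamine B assay, with a stated time of 48 h; on this read-out higher numbers stand for weaker inhibition of growth and lower numbers for stronger inhibition of growth.

Going by the values given here, compound 2, `ClCc1ccc(Cn2cnc3nc(Cl)nc(Cl)c32)cc1`, gives 15500 nM in this assay, the highest of the three numbers measured so far. Compound 1, `ClCc1cccc(Cn2cnc3c(Cl)ncnc32)c1`, gives 11800 nM, and the gap between compound 1 and compound 2 is within the scatter, so no order can be set between them. Among the compounds with values here, compound 3, `ClCc1ccccc1Cn1cnc2nc(Cl)nc(Cl)c21`, gives 2390 nM, and its gap to compound 2 lies beyond the scatter; compound 3 is the only member whose number is clearly separated from that of compound 2.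

Compound 4, `ClCc1ccc(Cn2cnc3ncnc(Cl)c32)cc1`, has not yet been measured. It differs from compound 2 in one place: hydrogen in place of chloro on an aromatic carbon. Within the data shown here, no step between measured compounds covers this change, so the expectation rests on the values of compound 1 and compound 2 alone, which sit within the scatter of each other despite differing in the chloro count on the core as well as in the benzyl substitution. The step from a 1.3-fold lower number from compound 2 to compound 4 (0.11 log units; within the scatter) is therefore expected to stay within the scatter, with no clear direction. For compound 4 the estimate in this assay is 12000 nM, with a range from 5000 nM to 30000 nM.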

Compound 4, concentration for 50% growth inhibition: 1770 nM
Compound 4: middle estimate off by 6.8-fold (0.83 log units), on the high side; the whole stated range lies above it.
By their numbers in this assay, from the lowest: compounds 4 and 3 (each within the scatter of the next); then compounds 1 and 2 (each within the scatter of the next).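

Going by these compounds alone, replacing chloro with hydrogen on the aromatic carbon between two ring nitrogen atoms gives an 8.8-fold lower number from compound 2 to compound 4 (0.94 log units; beyond the scatter) in this assay, the first change that can be read at a single place. The step lies beyond the scatter, so this position affects the read-out, and growth inhibition in this pair is stronger with hydrogen there than with chloro. No measurement at hand bears on what lies behind this step.

From the compounds shown here alone, whether the same change gives a step of similar size with the benzyl substitution of compound 1 or compound 3 remains open. Also open, going by these compounds, is how an amine or a methoxy group on this same aromatic carbon would compare with hydrogen and chloro.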